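This account rests on a few compounds, and the source may have more. Where it says the series, first, only, none or still open, it means among the compounds named here.

Compound 1, `O=C(CCCCCc1ccccc1)c1nc2cccnc2o1`: 1700 nM
Compound 2, `O=C(CCCCCCc1ccccc1)c1ccc(-c2ccco2)nn1`: > 10000 nM, a limit of the assay and not a number
Compound 3, `O=C(CCCCCCc1ccccc1)c1ncc(C(=O)C(F)(F)F)o1`: 1820 nM

All three were tested in an assay on HEK-293T cells for inhibition of diacylglycerol lipase-alpha (Homo sapiens), read by colorimetric assay; a higher number here means a weaker inhibitor, a lower number a stronger inhibitor. Compound 3 gives 1820 nM, the higher of the two numbers recorded, but its nearest neighbour, compound 1 at 1700 nM, lies within the scatter of it, so the two cannot be told apart. Compound 2 sits at the limit of > 10000 nM in this assay, at which 1 of the 3 values shown sits. For the measured compounds named here, no two of the measured compounds differ in one place only, so no measured step is available to lean on.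

Compound 4, `O=C(CCCCCCc1ccccc1)c1ncc(-c2ccc(F)cc2)o1`, has not yet been measured. Going by the values given here, its only difference from compound 3 is 4-fluorophenyl in place of (trifluoromethyl)carbonyl on an aromatic carbon. Among the compounds with values here, with no measured step of this kind on the shared core, the change is expected to leave the number roughly where compound 3 has it, a step of a 1.1-fold higher number from compound 3 to compound 4 (0.04 log units; within the scatter) that stays within the scatter, though with wide uncertainty in either direction. For compound 4 the estimate is 2000 nM, within a range of 400 nM to 10000 nM.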

Compound 4, half-maximal inhibitory concentration: > 10000 nM
Compound 4 gave a limit, no number; the forecaster's own chance of this, stated with the estimate: 25%; at least 5.0-fold (0.69 log units) between middle value and limit.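

On the aromatic carbon next to the ring oxygen, the choice of group matters: putting 4-fluorophenyl in place of (trifluoromethyl)carbonyl gives an at least 5.4-fold higher number from compound 3 to compound 4 (0.73 log units; beyond the scatter) in this assay. The earlier compounds shown here offered no pair differing in one place only, so they could not show that this position moves the number at all. The result for compound 4 is a limit of the assay and not a number: the limit of > 10000 nM in this assay, at which 2 of the 4 values shown sit.

A single swap cannot separate the loss of the (trifluoromethyl)carbonyl from the arrival of the 4-fluorophenyl, since both happen at once. Going by these compounds, it remains open how other groups would read at this position, such as a nitrile, a methyl ester or a phenyl ring without fluorine, and whether any of them would match compound 3 at 1820 nM.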